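Replacing the arylamine of compound 1 with a fluorophenyl

A few compounds are considered here, and "the series" means these few. Any claim that something is new, unique, unknown or untested is made for them only; others in the source may bear on it.

Compound 1, `C=C[C@@](C)(/C=C/c1ccc(Nc2ccc(OC)cc2)cc1)CCC=C(C)C` — > 36600 nM in an ADME assay on HEK293 cells (Homo sapiens) for cytotoxicity, with a stated time of 72 h; on this read-out lower numbers stand for an effect already at smaller amounts and higher numbers for an effect only at larger amounts of compound
Compound 2, `C=C[C@@](C)(/C=C/c1ccc(Nc2ccc(OC)c(OC)c2)cc1)CCC=C(C)C` — > 36600 nM
Compound 3, `C=C[C@@](C)(/C=C/c1ccc(Nc2ccc(OC(F)(F)F)cc2)cc1)CCC=C(C)C` — > 36600 nM

In this assay compound 1 is reported only as a limit, > 36600 nM, not as a number. Compound 2 likewise sits at a limit, > 36600 nM. Compound 3 also sits at a limit, > 36600 nM. Both steps from the parent are therefore unreadable: a step that the two limits leave unreadable from compound 1 to compound 2 and a step that the two limits leave unreadable from compound 1 to compound 3. The whole series is summed up by the limit of > 36600 nM in this assay, at which 3 of the 3 values shown sit; no measured value in this assay is a number.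

Compound 4, `C=C[C@@](C)(/C=C/c1ccc(-c2cccc(F)c2)cc1)CCC=C(C)C`, has not been measured yet. Its change from compound 1 is 3-fluorophenyl in place of (4-methoxyphenyl)amino on an aromatic carbon. Among the compounds with values here, neither measured step bears on this exchange, and no step is readable, so nothing in the data gives a direction or size. The expectation rests only on the fact that compound 1, compound 2 and compound 3 all stand at the limit (the limit of > 36600 nM in this assay, at which 3 of the 3 values shown sit); compound 4 is expected to stand there too, with an expected step that the limit leaves unreadable from compound 1 to compound 4. The estimate for compound 4 is 50000 nM, within 20000 nM to 150000 nM, most likely reported again as a limit.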

Compound 4, half-maximal effective concentration: > 36600 nM
Compound 4: a limit, no number; the forecaster's own chance of this, stated with the estimate: 75%; the middle value is on the limit's open side.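

Within the data shown here, compound 4, like compound 1, is reported only as a limit in this assay, so no step between the two can be read. The compounds shown leave open whether any of these exchanges alters the read-out at all: the limit of > 36600 nM in this assay, at which 4 of the 4 values shown sit.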